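Compound 1 to compound 3: a new aromatic group

The source may report more compounds than this note shows. Statements on the series, on what has been measured and on what is new or still open speak of the compounds shown alone.

Values in a functional assay on HCT-116 cells (Homo sapiens) for inhibition, read by MTT assay, with a stated time of 72 h; a lower number here means a stronger inhibitor, a higher number a weaker inhibitor:
- compound 1 `COc1cccc(Cn2c(=O)oc3cc(-c4cnc5[nH]ccc5c4)ccc32)c1`: 5000 nM
- compound 2 `COc1cc(Cn2c(=O)oc3cc(-c4cnc5[nH]ccc5c4)ccc32)ccc1F`: 8050 nM

Within the data shown here, compound 1 is not separated from the only other measured compound. Among the measured compounds shown here, the one measured step, fluoro in place of hydrogen on an aromatic carbon, is a 1.6-fold higher number from compound 1 to compound 2 (0.21 log units; within the scatter). Compound 3 `COc1cccc(Cn2c(=O)oc3cc(-c4ccc(N)nc4)ccc32)c1` differs from compound 1 by a group of 7 heavy atoms (5 carbon, 2 nitrogen; one six-membered aromatic ring with 1 hetero atom) in place of a group of 9 heavy atoms (7 carbon, 2 nitrogen; one five-membered aromatic ring with 1 hetero atom, one six-membered aromatic ring with 1 hetero atom), on an aromatic carbon, with 6-aminopyridin-3-yl as the entering group. For the measured compounds named here, no measured step covers this change, so the data give no size or direction for it, and no shift beyond the scatter is expected in this assay. The estimated step is a 1.2-fold higher number from compound 1 to compound 3 (0.08 log units; within the scatter). For compound 3 the expected value is 6000 nM, with an estimated range of 2000 nM to 20000 nM.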

Compound 3, half-maximal inhibitory concentration: 7440 nM
Compound 3: the middle estimate sits 1.2-fold (0.09 log units) below what was measured; measured number inside the range.
By their numbers in this assay, from the lowest: compounds 1, 3 and 2 (each within the scatter of the next).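

In this assay, placing 6-aminopyridin-3-yl on this aromatic carbon of the core gives a 1.5-fold higher number from compound 1 to compound 3 (0.17 log units; within the scatter). Among these compounds, this is the first variation at this position, and the five-membered aromatic ring of the group that leaves is not required to keep the number at this level. No measured evidence bears on this result.

From the compounds shown here alone, it remains open whether another group at this position, such as phenyl or morpholine, would move the number beyond the scatter. Also open, going by these compounds, is how a methyl group in place of the amine of 6-aminopyridin-3-yl would read.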